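The source may report more compounds than this note shows. Statements on the series, on what has been measured and on what is new or still open speak of the compounds shown alone.

Two compounds of the series have numbers in an ADME assay (liver) for metabolic stability, with Liver microsome (Rattus norvegicus) as the target, using microsomes and NADPH, with a stated time of 30 min, tested at 1 uM; on this read-out lower numbers stand for slow clearance and higher numbers for fast clearance. Compound 1 `Nc1ccc(S(=O)(=O)N2CCN(c3ncc(C(O)(C(F)(F)F)C(F)(F)F)cc3C#CC3CC3)CC2)cn1` gives 67 mL.min-1.g-1. Compound 2 `Nc1ccc(S(=O)(=O)N2CCN(c3ncc(C(O)(C(F)(F)F)C(F)(F)F)cc3-c3cccc(F)c3)CC2)cn1` gives 52 mL.min-1.g-1, which sits at the bottom of the two numbers shown, yet the step of a 1.3-fold lower number from compound 1 to compound 2 (0.11 log units; within the scatter) lies within the scatter, so the two compounds are not distinguished on this read-out. Compound 3 `COc1ccc(-c2cc(C(O)(C(F)(F)F)C(F)(F)F)cnc2N2CCN(S(=O)(=O)c3ccc(N)nc3)CC2)cn1` is not yet measured in this assay. It differs from compound 2 in one place: 6-methoxypyridin-3-yl in place of 3-fluorophenyl on an aromatic carbon. Among the measured compounds shown here, the only measured step at that aromatic carbon, a 1.3-fold lower number from compound 1 to compound 2 (0.11 log units; within the scatter), left the number within the scatter, and no measured step involving a 6-methoxypyridin-3-yl group is available. Compound 3 is therefore expected to give a number close to that of compound 2, with the step of a 1.0-fold lower number from compound 2 to compound 3 (0.02 log units; within the scatter) expected to stay within the scatter. The estimate for compound 3 is 50 mL.min-1.g-1, with a range from 25 mL.min-1.g-1 to 100 mL.min-1.g-1.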

Compound 3, intrinsic clearance in microsomes: 265 mL.min-1.g-1
Compound 3: the middle estimate sits 5.3-fold (0.72 log units) below what was measured; measured number above the stated range.
By their numbers in this assay, from the lowest: compounds 2 and 1 (each within the scatter of the next); then compound 3.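

At this aromatic carbon the group does matter in this assay: 6-methoxypyridin-3-yl gives a 5.1-fold higher number from compound 2 to compound 3 (0.71 log units; beyond the scatter) and a 4.0-fold higher number from compound 1 to compound 3 (0.60 log units; beyond the scatter), both toward fast clearance. The earlier exchange of 2-cyclopropylethynyl for 3-fluorophenyl stayed within the scatter, so the position is not indifferent to its substituent, although those two quite different groups could not be told apart on this read-out. Nothing shown here bears on why the number rises with this group.

The entering group brings a ring nitrogen and a methoxy group together, so the compounds shown cannot assign the rise to either one. From the compounds shown here alone, an unsubstituted pyridinyl group and a methoxyphenyl group at this carbon would separate the two, and how far each alone moves the clearance remains open.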